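A few compounds are considered here, and "the series" means these few. Any claim that something is new, unique, unknown or untested is made for them only; others in the source may bear on it.

Four compounds are compared here. Compound 1 `Nc1nc2c(c(-c3ccoc3)cn2[C@@H]2O[C@H](CO)[C@@H](O)[C@H]2O)c(=O)[nH]1` carries a furan-3-yl group on its core. In a functional assay on HCT-116 cells (Homo sapiens), read by MTT assay, with a stated time of 72 h (a higher number here means a weaker inhibitor, a lower number a stronger inhibitor), compound 1 gives 17600 nM. Compound 2 `Nc1nc2c(c(-c3cc4ccccc4o3)cn2[C@@H]2O[C@H](CO)[C@@H](O)[C@H]2O)c(=O)[nH]1` arises from compound 1 by the change (1-benzofuran-2-yl in place of furan-3-yl on an aromatic carbon). For compound 2 this assay reports only a limit, > 100000 nM, as recorded in the limit of > 100000 nM in this assay, at which 1 of the 3 values shown sits. That change made an at least 5.6-fold higher number from compound 1 to compound 2 (0.75 log units; beyond the scatter).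

Compound 3 `Nc1nc(N)c2c(-c3ccoc3)cn([C@@H]3O[C@H](CO)[C@@H](O)[C@H]3O)c2n1` has a different core from compound 1; the difference between the two cores is not broken down here. For compound 3 this assay also reports only a limit, > 20000 nM, as recorded in the limit of > 20000 nM in this assay, at which 1 of the 3 values shown sits.

Compound 4 `Nc1nc(N)c2c(-c3cc4ccccc4o3)cn([C@@H]3O[C@H](CO)[C@@H](O)[C@H]3O)c2n1` is not yet measured and arises from compound 3 by the same change, (1-benzofuran-2-yl in place of furan-3-yl on an aromatic carbon), at the same place as before. Because the earlier step was an at least 5.6-fold higher number from compound 1 to compound 2 (0.75 log units; beyond the scatter), compound 4 is expected to give a higher number than compound 3. The expected step is a step that the limit leaves unreadable from compound 3 to compound 4. Compound 4 is therefore estimated at 150000 nM, with a plausible range from 50000 nM to 500000 nM, and this assay will most likely again report only a limit for compound 4.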

Compound 4, half-maximal inhibitory concentration: 14000 nM
For compound 4 the middle estimate is 11-fold (1.03 log units) above the measured one; measured number below the stated range.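

In this assay the new step reads an at least 1.4-fold lower number from compound 3 to compound 4 (0.15 log units; that floor lies within the scatter). Set beside the earlier step, putting 1-benzofuran-2-yl in place of furan-3-yl did not give the same result on the two cores: the same change on two cores in this assay, an at least 5.6-fold higher number (0.75 log units; beyond the scatter) from compound 1 to compound 2 and an at least 1.4-fold lower number (0.15 log units; that floor lies within the scatter) from compound 3 to compound 4, at least 8.1-fold (0.90 log units) apart, beyond the scatter of two such steps. Going by these compounds, for these two pairs, then, the outcome of the change differs with the core, but compound 3 has only a limit, so the true size of its step stays unknown, compound 4 cannot be called stronger than compound 3, and two pairs give no rule for the whole series.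

The compounds shown leave open whether the same split between the two cores would appear with other groups at this place on the ring, such as a phenyl ring, an amine or a longer chain. They also leave open whether the split would be seen in any test other than this assay.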